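The source may report more compounds than this note shows. Statements on the series, on what has been measured and on what is new or still open speak of the compounds shown alone.

Working notes on the aryl-ether acid series. In an ADME assay on the whole organism (strain CD-1) for pharmacokinetics, with Mus musculus as the target, at a dose of 3 mg/kg by the intravenous route (on this read-out lower numbers stand for lower exposure and higher numbers for higher exposure at the dose given), compound 1 `C[C@H](CCCOc1ccccc1CN(C)C(=O)c1ccc(-c2ccco2)cc1)CC(=O)O` gives 77700 ng.h/mL. Its epimer compound 2 `C[C@@H](CCCOc1ccccc1CN(C)C(=O)c1ccc(-c2ccco2)cc1)CC(=O)O` gives 30800 ng.h/mL, and the step of a 2.5-fold lower number from compound 1 to compound 2 (0.40 log units; beyond the scatter) is the only one here that clears the scatter; it rests on (the fact that compounds 1 and 2 differ only in the configuration as drawn). Compound 3 `CN(Cc1ccccc1OCCC[C@@H]1C[C@H]1C(=O)O)C(=O)c1ccc(-c2ccco2)cc1` gives 40500 ng.h/mL in this assay, which places it second highest of the three, with the step of a 1.9-fold lower number from compound 1 to compound 3 (0.28 log units; within the scatter) and the step of a 1.3-fold higher number from compound 2 to compound 3 (0.12 log units; within the scatter) both inside the scatter. So the two exchanges of the acid-bearing chain that have been measured, from either epimer to compound 3, moved exposure little, while only the stereochemical flip changed it.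

The next step keeps the shared core and again rebuilds the acid-bearing chain: compound 4 `C/C(=C\COc1ccccc1CN(C)C(=O)c1ccc(-c2ccco2)cc1)CCC(=O)O` differs from compound 3 by 4-carboxy-2-methylbut-1-en-1-yl in place of 2-(2-carboxycyclopropyl)ethyl on a saturated chain carbon bound to an oxygen on an aromatic ring. The measured steps that bear on it are the two chain exchanges, both within scatter, so no step beyond the scatter is expected in this assay in either direction. Compound 4 is therefore expected to give about 35000 ng.h/mL, with a range of 14000 ng.h/mL to 85000 ng.h/mL, which is the expected step of a 1.2-fold lower number from compound 3 to compound 4 (0.06 log units; within the scatter).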

Compound 4, area under the concentration-time curve: 3300 ng.h/mL
Compound 4: middle estimate off by 11-fold (1.03 log units), on the high side; measured number outside the range, below it.
By their numbers in this assay, from the lowest: compound 4; then compounds 2, 3 and 1 (each within the scatter of the next, the first and the last beyond it).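

In this assay the acid-bearing chain no longer looks like a position that tolerates any rebuilding, as the exchange to the 5-carboxy-3-methylpent-2-en-1-yl chain gives a 12-fold lower number from compound 3 to compound 4 (1.09 log units; beyond the scatter), a 9.3-fold lower number from compound 2 to compound 4 (0.97 log units; beyond the scatter) and a 24-fold lower number from compound 1 to compound 4 (1.37 log units; beyond the scatter), leaving compound 4 lowest of the four and beyond the scatter of each earlier compound. Against compound 3, the entering and leaving groups have the same heavy-atom, donor and acceptor counts and no net charge, so these counts alone do not keep exposure in place; what differs is the three-membered ring, the stereocentres and the added double bond outside aromatic rings. Nothing on hand bears on why this exchange lowers exposure.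

Open, on these data alone, is whether the lower number goes with the loss of the three-membered ring, with the double bond, or with the branching methyl, as compound 4 changes these together. Also open, as far as these compounds go, is how a saturated 5-carboxy-3-methylpentyl chain, or a tetrazole in place of the carboxylic acid on the chain of compound 4, would read in this assay.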